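Chloro for Methyl on the Pyridine of Compound 2

The compounds below may be only part of what the source reports. "The series", "measured", "known", "first", "only" and "open" are said of these compounds alone.

Measured compounds:
compound 1, `CCc1cccc(-c2nn3c(c2-c2ccnc(Cl)c2)C(C)C(C)(C)C3)n1`, > 100000 nM
compound 2, `Cc1cc(-c2c(-c3cccc(C)n3)nn3c2C(C)C(C)(C)C3)ccn1`, > 100000 nM

In a functional assay on MCF7 cells (Homo sapiens) for cytotoxicity, with a stated time of 72 h (a higher number here means a weaker inhibitor, a lower number a stronger inhibitor), compound 1 gives > 100000 nM, which is a limit of the assay and not a number. In this assay compound 2 gives > 100000 nM, again a limit rather than a measured number. Thus compound 2 stands where the only other value shown also stands, at the limit of > 100000 nM in this assay, at which 2 of the 2 values shown sit. Going by the values given here, no step between measured compounds is available here, and the two structures differ in more than one place, so the two values show only that neither compound reached a measurable half-maximal inhibitory concentration.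

Compound 3, `Cc1cccc(-c2nn3c(c2-c2ccnc(Cl)c2)C(C)C(C)(C)C3)n1`, has not yet been measured in this assay. It differs from compound 2 by chloro in place of methyl on an aromatic carbon. Since both values shown in this assay are limits, there is no measured change on which to rest an expectation of a step in either direction, and compound 1, which carries the same chloro group, also sits at the limit. The step is therefore expected to be none beyond the scatter, a number no higher from compound 2 to compound 3 (the limit leaves the size open). Compound 3 is estimated at 100000 nM, with a range from 30000 nM to 300000 nM.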

Compound 3, half-maximal inhibitory concentration: > 100000 nM
Compound 3: no number, only a limit; the forecaster's own chance of this, stated with the estimate: 85%; the middle value lies on the limit itself.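

In this assay compound 3 gives > 100000 nM, which is a limit of the assay and not a number. The steps to compound 3 from compound 1 and from compound 2 therefore cannot be read, and all three compounds stand at the same limit: the limit of > 100000 nM in this assay, at which 3 of the 3 values shown sit.

The compounds shown leave open whether 2-methylpyridin-4-yl and 2-chloropyridin-4-yl differ at all in this assay.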